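The compounds below may be only part of what the source reports. "The series", "measured", "known", "first", "only" and "open" are said of these compounds alone.

Measured in a functional assay on QG-56 cells (Homo sapiens) for antiproliferative activity; a higher number here means a weaker inhibitor, a lower number a stronger inhibitor:

Compound 1 `COc1ccc(C(O)(c2cc3cc([N+](=O)[O-])cc(-c4ccccc4)c3o2)c2cncn2C)cc1`: 4970 nM
Compound 2 `Cn1cncc1[C@@](N)(c1ccc(C#N)cc1)c1cc2cc([N+](=O)[O-])cc(-c3ccccc3)c2o1`: 5.9 nM

Of these two, compound 1 has the higher number and is therefore the weaker inhibitor, and the gap lies beyond the scatter of repeated measurements. Compound 2 differs from compound 1 in more than one place, so its value says little about any single group.

Compound 3 `Cn1cncc1C(O)(c1ccc(C(=O)OC(C)(C)C)cc1)c1cc2cc([N+](=O)[O-])cc(-c3ccccc3)c2o1` keeps the rest of compound 1 and changes one group: tert-butoxycarbonyl in place of methoxy on an aromatic carbon. Within the data shown here, no measured pair shows what this swap does in this assay, so the best guide is compound 1 itself, at 4970 nM. With so little evidence, no step beyond the scatter is expected, and neither direction can be favoured. The estimated step is a 1.2-fold lower number from compound 1 to compound 3 (0.09 log units; within the scatter). For compound 3 the expected value is 4000 nM, with an estimated range of 1000 nM to 15000 nM.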

Compound 3, half-maximal inhibitory concentration: 6250 nM
Estimate against measurement, compound 3: 1.6-fold (0.19 log units) below, within the range that was stated.
By their numbers in this assay, from the lowest: compound 2; then compounds 1 and 3 (each within the scatter of the next).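

Replacing methoxy with the much larger tert-butoxycarbonyl, which has 7 heavy atoms rather than 2, gives a 1.3-fold higher number from compound 1 to compound 3 (0.10 log units; within the scatter) in this assay. At this place, on the six-membered aromatic ring and para to a large group, the two compounds therefore cannot be told apart, despite the added bulk and the extra hydrogen-bond acceptor. No measurement is at hand that could explain this result.

One swap cannot show whether other groups here, such as a carboxylic acid or an amine, would also leave the number within the scatter. The compounds shown also leave open which of the several differences in compound 2 goes with its far lower number, as no compound separates them.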